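Benzyl versus methyl: cytotoxicity notes on a small series

The compounds below may be only part of what the source reports. "The series", "measured", "known", "first", "only" and "open" are said of these compounds alone.

Three compounds have numbers in a functional assay on FM3A cells (Mus musculus) for cytotoxicity, read by cell counting, with a stated time of 2 days; on this read-out lower numbers stand for stronger inhibition and higher numbers for weaker inhibition. Compound 1 `C=C(Br)C(=O)Nc1ccc(/C=C2\SC(=O)N(Cc3ccccc3)C2=O)cc1` gives 3000 nM, compound 2 `C=C(Br)C(=O)Nc1ccc(/C=C2\SC(=O)N(C)C2=O)cc1` gives 750 nM, and compound 3 `CN1C(=O)S/C(=C\c2ccc(N)cc2)C1=O` gives 107000 nM. Compound 4 `Nc1ccc(/C=C2\SC(=O)N(Cc3ccccc3)C2=O)cc1` has not yet been measured.

Compound 1 and compound 2 share one core and differ by phenyl in place of hydrogen on a saturated chain carbon bound to an amide-type nitrogen in a ring. The step of a 4.0-fold higher number from compound 2 to compound 1 (0.60 log units; beyond the scatter). Compound 3 carries the other core; it differs from compound 2 by hydrogen in place of (1-bromoethenyl)carbonyl on a nitrogen on an aromatic ring, and the step of a 140-fold higher number from compound 2 to compound 3 (2.15 log units; beyond the scatter). Compound 3 thus stands highest of the three numbers, with compound 1 nearest to it.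

Compound 4 differs from compound 3 by phenyl in place of hydrogen on a saturated chain carbon bound to an amide-type nitrogen in a ring. This is the same change as from compound 2 to compound 1, now made on the other core; the place is the same in both cases. The expectation for compound 4 rests on one earlier step, a 4.0-fold higher number from compound 2 to compound 1 (0.60 log units; beyond the scatter), applied to the starting point of compound 3, which gives 107000 nM. Whether the change behaves alike on both cores cannot be checked with these three numbers, so the range is kept wide. Compound 4 is expected in this assay at 350000 nM, between 120000 nM and 1000000 nM. The estimated step is a 3.3-fold higher number from compound 3 to compound 4 (0.51 log units; beyond the scatter), expected to match the size of the earlier one. Compound 3 already gives 107000 nM, the highest of the three measured numbers.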

Compound 4, half-maximal inhibitory concentration: 24000 nM
Compound 4: middle estimate off by 15-fold (1.16 log units), on the high side; measured number below the stated range.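

In this assay, methyl to benzyl on the core of compound 3 gives a 4.5-fold lower number from compound 3 to compound 4 (0.65 log units; beyond the scatter), so the change does not carry over from the core of compound 2, where it raised the number, and the direction itself reverses: the same change on two cores in this assay, a 4.0-fold higher number (0.60 log units; beyond the scatter) from compound 2 to compound 1 and a 4.5-fold lower number (0.65 log units; beyond the scatter) from compound 3 to compound 4, 18-fold (1.25 log units) apart, beyond the scatter of two such steps. Read the other way, taking the (1-bromoethenyl)carbonyl group off the nitrogen on the aromatic ring raises the number much less in the benzyl pair, with an 8.0-fold higher number from compound 1 to compound 4 (0.90 log units; beyond the scatter), than in the methyl pair: the same change on two cores in this assay, a 140-fold higher number (2.15 log units; beyond the scatter) from compound 2 to compound 3 and an 8.0-fold higher number (0.90 log units; beyond the scatter) from compound 1 to compound 4, 18-fold (1.25 log units) apart, beyond the scatter of two such steps. Both comparisons rest on the same four compounds and a single read-out, so they show that the two changes do not add independently in this series, but they do not show why, nor which direction a further core would follow.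

The compounds shown leave open whether the reversal depends on the bromine-bearing acyl group itself, which an acetyl or plain acryloyl group on the same nitrogen would test. They also leave open how the trend runs along the chain on the ring nitrogen, for example with ethyl or phenethyl in place of methyl or benzyl on both cores.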